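A few compounds are considered here, and "the series" means these few. Any claim that something is new, unique, unknown or untested is made for them only; others in the source may bear on it.

In a functional assay on HL-60 cells (Homo sapiens) for cytotoxicity, read by MTT assay, with a stated time of 24 h (a lower number here means a stronger inhibitor, a higher number a weaker inhibitor), compound 1, `CC(C)(C)c1ccc(-c2nn(CCCN3CCN(c4ccccc4)CC3)c(=S)[nH]2)cc1`, gives > 300000 nM, which is a limit of the assay rather than a number. Compound 2, `CC(C)(C)c1ccc(-c2nn(CCCN3CCN(c4cccc(Cl)c4)CC3)c(=S)[nH]2)cc1`, gives > 300000 nM in this assay, again a limit and not a measured number. Within the data shown here, the one measured step, a step that the two limits leave unreadable from compound 1 to compound 2, is accordingly not readable in size or direction, and all the two values show together is the limit of > 300000 nM in this assay, at which 2 of the 2 values shown sit. So compound 2 stands at that limit, with no number of its own to build on. Compound 3, `Cc1ccc(-c2nn(CCCN3CCN(c4cccc(Cl)c4)CC3)c(=S)[nH]2)cc1`, differs from compound 2 by methyl in place of tert-butyl on an aromatic carbon. Among the measured compounds shown here, no measured step bears directly on this change, and the only step in the set is itself unreadable, so there is no basis for expecting a move in this assay in either direction beyond the scatter. Compound 3 is therefore expected to give about 300000 nM, within an estimated range of 100000 nM to 1000000 nM, most likely reported once more as a limit. The step this estimate means is a number no higher from compound 2 to compound 3 (the limit leaves the size open), which is expected to be none beyond the scatter.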

Compound 3, half-maximal inhibitory concentration: > 300000 nM
Compound 3: no number, only a limit; the forecaster's own chance of this, stated with the estimate: 80%; the middle value sits exactly at the limit.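

In this assay compound 3 gives > 300000 nM as a limit of the assay and not a number. With compound 2 also reported only as a limit, the step between compound 2 and compound 3 cannot be read. The compounds shown leave open how strongly any of them acts on these cells, and whether either change alters that.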